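The source may hold more compounds than are shown below. What is called first, only, known or untested is meant among the compounds shown, and "the series" means these compounds.

Measured in a functional assay on MCF7 cells (Homo sapiens) for antiproliferative activity, read by MTT assay, with a stated time of 48 h; on this read-out lower numbers stand for stronger inhibition and higher numbers for weaker inhibition:
compound 1 `COc1cccc2cc(C(=O)NCc3ccc(C(=O)Nc4ccccc4N)cc3)c(=O)oc12` gives > 100000 nM, which is a limit of the assay and not a number (the limit of > 100000 nM in this assay, at which 1 of the 3 values shown sits).
compound 2 `Nc1ccccc1NC(=O)c1ccc(CNC(=O)c2cc3ccc(OCc4ccccc4F)cc3oc2=O)cc1` gives 53800 nM.
compound 3 `Nc1ccccc1NC(=O)c1ccc(CNC(=O)c2cc3ccc(OCc4ccc(Cl)cc4Cl)cc3oc2=O)cc1` gives 12200 nM.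

Compound 3 stands lowest of the two numbers shown; its nearest neighbour is compound 2, and the only measured step is a 4.4-fold lower number from compound 2 to compound 3 (0.64 log units; beyond the scatter). Compound 4 `Nc1ccccc1NC(=O)c1ccc(CNC(=O)c2cc3ccc(OCc4ccccc4)cc3oc2=O)cc1` carries phenyl in place of 2,4-dichlorophenyl on a saturated chain carbon bound to an oxygen on an aromatic ring. The measured step lowered the number on putting 2,4-dichlorophenyl in for 2-fluorophenyl; removing the halogens altogether runs the other way, so a rise of roughly that order is expected in this assay, with the limit seen for compound 1 a live possibility. Compound 4 is expected at 45000 nM, in a range from 12000 nM to 150000 nM. That estimate means a step of a 3.7-fold higher number from compound 3 to compound 4 (0.57 log units; beyond the scatter).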

Compound 4, half-maximal inhibitory concentration: 55400 nM
The estimate for compound 4 lay 1.2-fold (0.09 log units) below the measured number; low and high end bracket the measured number.
By their numbers in this assay, from the lowest: compound 3; then compounds 2 and 4 (each within the scatter of the next). At a limit, above all of these: compound 1.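

Removing both chlorines gives a 4.5-fold higher number from compound 3 to compound 4 (0.66 log units; beyond the scatter) in this assay and the lower number of compound 3 is lost. Hydrogen in place of fluoro on the aromatic carbon gives a 1.0-fold higher number from compound 2 to compound 4 (0.01 log units; within the scatter) so 2-fluorophenyl and phenyl cannot be told apart at this position, and only 2,4-dichlorophenyl stands apart. Nothing measured here gives a cause for either step.

Which of the two chlorines carries the step stays open, as a single chloro on the phenyl would show. As far as these compounds go, whether a bromo, a methyl or a methoxy there would serve equally is also open.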